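Ethoxy in Place of Cyclopropyl on an Aromatic Carbon

The compounds below may be only part of what the source reports. "The series", "measured", "known", "first", "only" and "open" are said of these compounds alone.

Measured compounds:
compound 1 `O=C(O)C1CCN(c2ccccc2)C1` — 48000 nM
compound 2 `Cc1cc(C(=O)O)c(C)n1-c1cccc(C2CC2)c1` — 580 nM

Within the data shown here, in an assay on cells for inhibition of Palmitoleoyl-protein carboxylesterase NOTUM variant C330S (Homo sapiens), read by fluorescence, with a stated time of 40 min (a higher number here means a weaker inhibitor, a lower number a stronger inhibitor), compound 2 has the lowest of the two numbers known; its nearest neighbour is compound 1, whose number stands far higher, beyond the scatter. Compound 3 `CCOc1cccc(-n2c(C)cc(C(=O)O)c2C)c1` differs from compound 2 by ethoxy in place of cyclopropyl on an aromatic carbon. No step between measured compounds matches this change, so its size is not shown anywhere in these data. In this assay a small step is expected, with no firm direction, most likely within the scatter. Compound 3 is expected to give 700 nM, with a range from 250 nM to 2000 nM. The expected step is estimated as a 1.2-fold higher number from compound 2 to compound 3 (0.08 log units; within the scatter).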

Compound 3, half-maximal inhibitory concentration: 640 nM
For compound 3 the middle estimate is 1.1-fold (0.04 log units) above the measured one, and the stated range covers the measured number.
By their numbers in this assay, from the lowest: compounds 2 and 3 (each within the scatter of the next); then compound 1.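

In this assay, putting ethoxy in place of cyclopropyl on this aromatic carbon, meta to a large group, gives a 1.1-fold higher number from compound 2 to compound 3 (0.04 log units; within the scatter). At this position, then, the three-membered carbon ring can give way to an open chain carrying an oxygen with no shift beyond the scatter. No measurement of any property of these groups bears on this result. The compounds shown leave open whether an amine, a methoxy or a longer chain such as propoxy at this carbon would read the same, and whether ethoxy would do so elsewhere on the ring.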